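The compounds below may be only part of what the source reports. "The series", "measured", "known", "first", "only" and "open" are said of these compounds alone.

Measured so far in a functional assay on HT-29 cells (Homo sapiens) for inhibition, read by MTT assay, with a stated time of 3 days; a lower number here means a stronger inhibitor, a higher number a weaker inhibitor

Compound 1 (`C=CCOc1cc(/C=C\c2cc(OC)c(OC)c(OC)c2)ccc1OC`) gives 29000 nM
Compound 2 (`COc1cccc(/C=C/CCCOc2cc(/C=C\c3cc(OC)c(OC)c(OC)c3)ccc2OC)c1`) gives 25000 nM
Compound 3 (`COc1ccc(/C=C/CCCOc2cc(/C=C\c3cc(OC)c(OC)c(OC)c3)ccc2OC)cc1`) gives 47000 nM

All three values lie within the usual scatter of one another. Compound 3 stands close to both others, with a 1.6-fold higher number from compound 1 to compound 3 (0.21 log units; within the scatter) and a 1.9-fold higher number from compound 2 to compound 3 (0.27 log units; within the scatter) as its steps. The change leading to compound 4 (`COc1ccc(/C=C\c2cc(OC)c(OC)c(OC)c2)cc1OCCC/C=C/c1ccc(F)cc1`) is fluoro in place of methoxy on an aromatic carbon in which fluoro replaces methoxy on an aromatic carbon, para to a large group, so that 4-methoxyphenyl becomes 4-fluorophenyl. Going by the values given here, no measured pair makes this exchange. The nearest evidence is the shift of the methoxy group (a 1.9-fold higher number from compound 2 to compound 3 (0.27 log units; within the scatter)), and the larger exchange of the whole chain also stayed within the scatter (a 1.2-fold lower number from compound 1 to compound 2 (0.06 log units; within the scatter)). On these steps, no change beyond the scatter is expected in this assay and no direction is favoured. The expected step is a 1.2-fold lower number from compound 3 to compound 4 (0.09 log units; within the scatter) as a rough estimate. Compound 4 is estimated at 38000 nM with an expected range from 16000 nM to 85000 nM as a cautious guide.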

Compound 4, half-maximal inhibitory concentration: 98000 nM
Beside the measured number, compound 4's estimate is 2.6-fold (0.41 log units) below it; the measured number lies above the stated range.
By their numbers in this assay, from the lowest: compounds 2, 1 and 3 (each within the scatter of the next); then compound 4.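

In this assay, going by these compounds alone, fluoro in place of methoxy on an aromatic carbon, para to a large group, gives a 2.1-fold higher number from compound 3 to compound 4 (0.32 log units; beyond the scatter) and is the first change to move the number beyond the scatter. Compound 4 also separates from the two other compounds, with a 3.9-fold higher number from compound 2 to compound 4 (0.59 log units; beyond the scatter) and a 3.4-fold higher number from compound 1 to compound 4 (0.53 log units; beyond the scatter) as its steps, whereas the two methoxy-bearing chains stayed within the scatter of compound 1 and of each other. No measurement shown here accounts for this shift.

The compounds leave open whether the higher number follows from losing methoxy or from adding fluoro, a question that a plain phenyl end or a 4-chlorophenyl end could help separate. On these data alone, how an amine or a carboxylic acid on this same aromatic carbon would compare also remains open.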